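Swapping cyclohexyl for 2-chlorophenyl on the urea series

The compounds below may be only part of what the source reports. "The series", "measured", "known", "first", "only" and "open" are said of these compounds alone.

Measured so far in a functional assay on MGC-803 cells (Homo sapiens) for antiproliferative activity, read by MTT assay, with a stated time of 48 h; on this read-out higher numbers stand for weaker inhibition and lower numbers for stronger inhibition:
Compound 1 `O=C(Nc1cccc(CNc2nccnc2Cl)c1)Nc1ccc(F)c(Cl)c1` gives 5020 nM
Compound 2 `CCc1ccccc1NC(=O)Nc1cccc(CNc2nccnc2Cl)c1` gives 9370 nM
Compound 3 `O=C(Nc1cccc(CNc2nccnc2Cl)c1)NC1CCCCC1` gives > 40000 nM

The value of compound 3 is a limit and not a number. Among the measured compounds, compound 3 alone stands at the limit of > 40000 nM in this assay, at which 1 of the 3 values shown sits. Compounds 1 and 2 do give numbers, and the step between them, a 1.9-fold higher number from compound 1 to compound 2 (0.27 log units; within the scatter), stays within the scatter.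

Compound 4 `O=C(Nc1cccc(CNc2nccnc2Cl)c1)Nc1ccccc1Cl` is the next to be considered. It carries 2-chlorophenyl in place of cyclohexyl on an amide-type nitrogen.

The closest evidence comes from the reverse kind of change, where 3-chloro-4-fluorophenyl or 2-ethylphenyl gives way to cyclohexyl. These steps are an at least 7.9-fold higher number from compound 1 to compound 3 (0.90 log units; beyond the scatter) and an at least 4.2-fold higher number from compound 2 to compound 3 (0.63 log units; beyond the scatter), and both lie beyond the scatter. On these data alone, each is bounded on one side only, so their full size remains open. Both of the compounds that carry a substituted phenyl here give numbers, and compound 4 is expected to join them, with a lower number in this assay and so stronger inhibition. The expected change is an at least 5.0-fold lower number from compound 3 to compound 4 (0.69 log units; beyond the scatter).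

For compound 4 the estimated value is 8000 nM, with an expected range from 3000 nM to 22000 nM.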

Compound 4, half-maximal inhibitory concentration: 7130 nM
The estimate for compound 4 lay 1.1-fold (0.05 log units) above the measured number, and the stated range covers the measured number.
By their numbers in this assay, from the lowest: compounds 1, 4 and 2 (each within the scatter of the next). At a limit, above all of these: compound 3.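

In this assay, going by these compounds alone, the change from cyclohexyl to 2-chlorophenyl on an amide-type nitrogen, so far seen only in the reverse direction with other groups, gives an at least 5.6-fold lower number from compound 3 to compound 4 (0.74 log units; beyond the scatter) and adds a third substituted phenyl group that returns a number where the cyclohexyl compound does not. Chloro in place of ethyl on an aromatic carbon gives a 1.3-fold lower number from compound 2 to compound 4 (0.12 log units; within the scatter) and 2-chlorophenyl in place of 3-chloro-4-fluorophenyl gives a 1.4-fold higher number from compound 1 to compound 4 (0.15 log units; within the scatter) so these three substituted phenyl groups cannot be told apart in this assay even though their substituents differ in kind and in place. On these data alone, the full size of the step away from cyclohexyl stays open on one side, since compound 3 stands at a limit and not at a number: the limit of > 40000 nM in this assay, at which 1 of the 4 values shown sits.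

The compounds shown leave open whether the chlorine contributes at all, as the plain phenyl group is not among them. They also do not tell whether a pyridyl ring or a benzyl group on the same nitrogen would keep the inhibition seen with the substituted phenyl groups.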